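The source may hold more compounds than are shown below. What is called first, only, known or untested is meant among the compounds shown, and "the series" means these compounds.

Measured compounds:
Compound 1, `CC(c1ccc(-c2ccccc2)c(F)c1)c1nnc2n1N=C(c1ccc(C(F)(F)F)cc1)CS2`, gives 9400 nM in a functional assay on Huh-7 cells (Homo sapiens) for inhibition, read by sulforhodamine B assay, with a stated time of 72 h; a higher number here means a weaker inhibitor, a lower number a stronger inhibitor.
Compound 2, `COc1ccc2cc(C(C)c3nnc4n3N=C(c3ccc(C(F)(F)F)cc3)CS4)ccc2c1`, gives 14800 nM in this assay.
Compound 3, `Cc1ccc(C2=Nn3c(nnc3C(C)c3ccc(-c4ccccc4)c(F)c3)SC2)cc1`, gives 7200 nM in this assay.

Compound 4, `COc1ccc2cc(C(C)c3nnc4n3N=C(c3ccc(C)cc3)CS4)ccc2c1`, has not yet been measured in this assay. Compound 1 and compound 3 share a core and differ in one place: methyl in place of trifluoromethyl on an aromatic carbon. This change made a 1.3-fold lower number from compound 1 to compound 3 (0.12 log units; within the scatter). Compound 2 rests on a different core; how the cores of compound 2 and compound 1 differ is not broken down here, and their two values in this assay lie within the scatter of each other. Compound 4 is drawn from compound 2 by the same change: methyl in place of trifluoromethyl on an aromatic carbon. Because the measured step of a 1.3-fold lower number from compound 1 to compound 3 (0.12 log units; within the scatter) stayed within the scatter, the step from compound 2 to compound 4 is expected to be of a similar size, a 1.3-fold lower number from compound 2 to compound 4 (0.11 log units; within the scatter). This expectation rests on one measured pair only, so it is held loosely. Compound 4 is accordingly estimated to give 11500 nM in this assay, with a range from 5500 nM to 24000 nM.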

Compound 4, half-maximal inhibitory concentration: 8200 nM
Beside the measured number, compound 4's estimate is 1.4-fold (0.15 log units) above it; low and high end bracket the measured number.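

In this assay, methyl in place of trifluoromethyl on the core of compound 2 gives a 1.8-fold lower number from compound 2 to compound 4 (0.26 log units; within the scatter), so this step, like the earlier one on the core of compound 1, stays within the scatter. With both steps inside the scatter, the pairs do not show that the change has a real effect on either core, and two cores alone cannot show how it would behave on a third. What they do show is that the step, read on these two cores, carries over without a difference that can be told apart, the two steps being no further from each other than such steps can be expected to lie: the same change on two cores in this assay, a 1.3-fold lower number (0.12 log units; within the scatter) from compound 1 to compound 3 and a 1.8-fold lower number (0.26 log units; within the scatter) from compound 2 to compound 4, 1.4-fold (0.14 log units) apart, within the scatter of two such steps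

The compounds shown leave open how an amine, a carboxylic acid or a longer chain would read in place of the trifluoromethyl on the same aromatic ring. They also leave open whether the step from 4-(trifluoromethyl)phenyl to 4-methylphenyl would stay this small on any other core.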